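A few compounds are considered here, and "the series" means these few. Any claim that something is new, unique, unknown or untested is made for them only; others in the source may bear on it.

Measured compounds:
Compound 1, `ClCc1cccc(Cn2cnc3ncnc(Cl)c32)c1`: 24000 nM
Compound 2, `ClCc1cccc(Cn2cnc3c(Cl)ncnc32)c1`: 66100 nM
Compound 3, `ClCc1cccc(Cn2cnc3c(Cl)nc(Cl)nc32)c1`: 5370 nM

All three were tested in a functional assay on NCI-H522 cells (Homo sapiens) for cytotoxicity, read by sulforhodamine B assay, with a stated time of 48 h; on this read-out higher numbers stand for weaker inhibition of growth and lower numbers for stronger inhibition of growth. Compound 1 and compound 2 are built from the same atoms joined differently; the difference between the two cores is not broken down here, and compound 2 gives the higher number of the two. Compound 3 differs from compound 2 by a single change, (chloro in place of hydrogen on an aromatic carbon), which produced a 12-fold lower number from compound 2 to compound 3 (1.09 log units; beyond the scatter). Compound 4, `ClCc1cccc(Cn2cnc3nc(Cl)nc(Cl)c32)c1`, has not yet been tested. It stands to compound 1 exactly as compound 3 stands to compound 2: the change is chloro in place of hydrogen on an aromatic carbon, in the same surroundings. Because that change once gave a 12-fold lower number from compound 2 to compound 3 (1.09 log units; beyond the scatter), compound 4 is expected to show a 9.6-fold lower number from compound 1 to compound 4 (0.98 log units; beyond the scatter), allowing that the other core may alter the size. The estimate for compound 4 is 2500 nM.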

Compound 4, concentration for total growth inhibition: 3540 nM
Compound 4: the middle estimate sits 1.4-fold (0.15 log units) below what was measured, within the range that was stated.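

In this assay chloro in place of hydrogen on an aromatic carbon gives a 6.8-fold lower number from compound 1 to compound 4 (0.83 log units; beyond the scatter) on the second core. Set beside the first case, the step carries over from one core to the other, and its size cannot be told apart between them: the same change on two cores in this assay, a 12-fold lower number (1.09 log units; beyond the scatter) from compound 2 to compound 3 and a 6.8-fold lower number (0.83 log units; beyond the scatter) from compound 1 to compound 4, 1.8-fold (0.26 log units) apart, within the scatter of two such steps. This rests on just two pairs of compounds in one cell line, so it does not establish a rule for other cores, and it does not explain why the change lowers the number.

Among the compounds shown, only hydrogen and chloro occupy this ring carbon. Going by these compounds, how an amine or a methoxy group would behave there remains open, as does whether the step would hold in other cells.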